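Piperazinyl for methylsulfanyl on a fused pyrazolopyrimidine core

The source may report more compounds than this note shows. Statements on the series, on what has been measured and on what is new or still open speak of the compounds shown alone.

Measured compounds:
compound 1 `CSc1nc(NCc2ccc(-c3ccccn3)cc2)c2[nH]nc(C(C)C)c2n1`, 778 nM
compound 2 `CC(C)c1n[nH]c2c(NCc3ccc(-c4ccccn4)cc3)nc(S(C)(=O)=O)nc12`, 640 nM

In a functional assay on K562 cells (Homo sapiens) for cytotoxicity, read by fluorescence, with a stated time of 72 h (on this read-out lower numbers stand for stronger inhibition and higher numbers for weaker inhibition), compound 1 gives 778 nM, and compound 2 gives 640 nM; the two numbers lie within the scatter of each other, as the step of a 1.2-fold lower number from compound 1 to compound 2 (0.08 log units; within the scatter) shows. Compound 3 `CC(C)c1n[nH]c2c(NCc3ccc(-c4ccccn4)cc3)nc(N3CCNCC3)nc12` differs from compound 1 by piperazin-1-yl in place of methylsulfanyl on an aromatic carbon. For the measured compounds named here, the only measured step at that carbon, a 1.2-fold lower number from compound 1 to compound 2 (0.08 log units; within the scatter), changed nothing beyond the scatter, and no step with piperazin-1-yl exists here. A modest shift is therefore expected, direction uncertain, a 1.6-fold lower number from compound 1 to compound 3 (0.19 log units; within the scatter). Compound 3 is estimated at 500 nM, between 150 nM and 1600 nM.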

Compound 3, half-maximal inhibitory concentration: 17 nM
Compound 3: the middle estimate sits 29-fold (1.47 log units) above what was measured; measured number outside the range, below it.
By their numbers in this assay, from the lowest: compound 3; then compounds 2 and 1 (each within the scatter of the next).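

The carbon between two ring nitrogen atoms, where methylsulfonyl for methylsulfanyl changed nothing beyond the scatter, turns out to be sensitive to the group it carries. In this assay, piperazin-1-yl gives a 46-fold lower number from compound 1 to compound 3 (1.66 log units; beyond the scatter) and a 38-fold lower number from compound 2 to compound 3 (1.58 log units; beyond the scatter), so the two sulfur groups are alike here, while the piperazine stands well apart from both. Unlike methylsulfanyl, piperazin-1-yl brings a six-membered non-aromatic ring and a hydrogen-bond donor.

Going by these compounds, whether morpholine or an open-chain amine such as dimethylamino would match it at this carbon remains open. Nothing available accounts for the size of these steps.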